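Bis(pyridyl) hydrazone acylated with a bromobenzoyl group

The compounds below may be only part of what the source reports. "The series", "measured", "known", "first", "only" and "open" are said of these compounds alone.

Measured compounds:
compound 1, `O=C(NN=C(c1ccccn1)c1ccccn1)c1cccs1`, 950 nM
compound 2, `O=C(N/N=C/c1ccccn1)c1ccc(O)cc1`, > 80000 nM
compound 3, `C/C(=N\NC(=O)c1ccccc1)c1cnccn1`, 3620 nM

In an ADME assay on cells (Homo sapiens) for antiproliferative activity, read by MTT assay (on this read-out higher numbers stand for weaker inhibition and lower numbers for stronger inhibition), compound 1 gives 950 nM, the lowest of the two numbers reported. The nearest neighbour is compound 3 with 3620 nM; the gap between these two lies beyond the usual scatter, so compound 1 is the stronger inhibitor of the pair. Compound 2 returns > 80000 nM, which is not a number but a limit of the assay, namely (the limit of > 80000 nM in this assay, at which 1 of the 3 values shown sits).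

The step of interest moves from compound 1 to compound 4, `O=C(NN=C(c1ccccn1)c1ccccn1)c1ccc(Br)cc1`. The change is 4-bromophenyl in place of thiophen-2-yl on a carbonyl carbon. The hydrazone part of the molecule, carrying both pyridyl rings on the imine carbon, is kept; only the acyl aromatic ring is exchanged. Going by the values given here, no measured pair in this set shows an exchange of the acyl ring on a shared hydrazone, so the size of the step cannot be read from the data. Since both groups are single aromatic rings of comparable size attached to the same carbonyl carbon, the step from compound 1 to compound 4 is expected to stay within the scatter, a 1.4-fold higher number from compound 1 to compound 4 (0.14 log units; within the scatter). Compound 4 is therefore estimated at 1300 nM in this assay, within a range of 450 nM to 4000 nM.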

Compound 4, half-maximal inhibitory concentration: 300 nM
Compound 4: middle estimate off by 4.3-fold (0.64 log units), on the high side; measured number below the stated range.
By their numbers in this assay, from the lowest: compound 4; then compound 1; then compound 3. At a limit, above all of these: compound 2.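

With the hydrazone part held fixed, the acyl ring on this carbonyl carbon proves not to be a neutral exchange in this assay: 4-bromophenyl in place of thiophen-2-yl gives a 3.2-fold lower number from compound 1 to compound 4 (0.50 log units; beyond the scatter). Going by these compounds alone, the earlier compounds differ from one another in more than one place, so this is the first step in the set that ties a change in the number to this position alone, and it shows that an exchange here can lower the number while both pyridyl rings stay on the imine carbon. Within the data shown here, the single pair cannot separate the contribution of the bromine from that of replacing the five-membered ring with a six-membered one, and nothing measured in the data accounts for the step.

The compounds shown leave open whether a plain phenyl ring on the same carbonyl carbon would keep the lower number or whether a methoxy group, an amine or a carboxylic acid in place of the bromine would change it. They also leave open whether the same exchange would have a similar effect on a hydrazone carrying a single pyridyl ring.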